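Purine-glycine amides in the oral tail flick test

The source may hold more compounds than are shown below. What is called first, only, known or untested is meant among the compounds shown, and "the series" means these compounds.

Measured compounds:
Compound 1 `NC(=O)CC[C@H](NC(=O)CN(c1ncnc2c1ncn2C1CCCCO1)C1CC1)C(=O)OCc1ccccc1` — 22.3%
Compound 2 `O=C(CN(c1nc(Cl)nc2[nH]cnc12)C1CC1)N[C@@H](CCC(=O)OCc1ccccc1)C(=O)OCc1ccccc1` — 45.9%
Compound 3 `CC(C)[C@H](NC(=O)CN(c1nc(Cl)nc2[nH]cnc12)C1CC1)C(=O)O` — 17.1%

The read-out is a functional assay on the whole organism (Tail, strain ICR) with Mus musculus as the target, in the tail flick test, with a stated time of 120 min, at a dose of 25 umol/kg by the oral route; on this read-out higher numbers stand for a stronger effect at the one dose given and lower numbers for a weaker effect. On the three numbers shown, compound 1 stands second highest. Its nearest neighbour is compound 3, whose value lies lower by an amount within the scatter, so no order between compound 1 and compound 3 can be claimed. Compound 2 lies furthest from compound 1, higher by an amount beyond the scatter.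

Compound 4 `CSCC[C@H](NC(=O)CN(c1ncnc2c1ncn2C1CCCCO1)C1CC1)C(=O)OCc1ccccc1` has not yet been measured in this assay. It differs from compound 1 in one place: methylsulfanyl in place of carbamoyl on a saturated chain carbon, three bonds along the chain from an amide-type nitrogen and a carbonyl carbon. Compound 4 keeps the benzyl ester and the core of compound 1; only the side chain of the amino acid residue is changed. For the measured compounds named here, no step between measured compounds matches this change, so its size cannot be read from the series. Since compound 1 and compound 3, which differ in more than one place, sit within the scatter of each other, a small step is expected, and its direction is uncertain. The step from compound 1 to compound 4 is estimated as a number 4.7 percentage points higher from compound 1 to compound 4 (within the scatter). For compound 4 the expected value in this assay is 27%, with a range from 10% to 48%.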

Compound 4, a percentage reported as activity, at one dose (the size of the read-out at that dose, not a potency): 28.7%
Beside the measured number, compound 4's estimate is 1.7 percentage points below it; measured number inside the range.
By their numbers in this assay, from the lowest: compounds 3, 1 and 4 (each within the scatter of the next, the first and the last beyond it); then compound 2.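

In this assay, for the compounds shown here, the one exchange that can be read alone, methylsulfanyl in place of carbamoyl on a saturated chain carbon, gives a number 6.4 percentage points higher from compound 1 to compound 4 (within the scatter). With the benzyl ester and the core of compound 1 kept, the change removes the one hydrogen-bond donor of carbamoyl and keeps one hydrogen-bond acceptor, yet this read-out at the one dose given does not separate the two compounds. No measurement shown here accounts for how closely the two compounds read.

From the compounds shown here alone, whether a carboxylic acid, an amine or a longer chain on this carbon would move the read-out beyond the scatter stays open. Also open, going by these compounds, is whether the same exchange would read alike on a core other than that of compound 1, or at another dose or time.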